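This account rests on a few compounds, and the source may have more. Where it says the series, first, only, none or still open, it means among the compounds named here.

Measured so far:
compound 1, `CC(=O)OCCOn1cnc2c(S)nc(F)nc21`, in a functional assay on FM3A cells (Homo sapiens) for inhibition, with FM3A (Mus musculus) as the target (a lower number here means a stronger inhibitor, a higher number a weaker inhibitor), compound 1 gives 136000 nM.
compound 2, `CC(O)n1cnc2c(S)nc(F)nc21`, in this assay compound 2 shows only the limit > 500000 nM.

For the measured compounds named here, compound 2 therefore has no number of its own in this assay; it sits at the limit of the method, as stated in the limit of > 500000 nM in this assay, at which 1 of the 2 values shown sits, and the only number in the set belongs to compound 1. Going by the values given here, no step between measured compounds is available.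

Compound 3, `OCCOn1cnc2c(S)nc(F)nc21`, remains to be measured. It differs from compound 2 by 2-hydroxyethoxy in place of 1-hydroxyethyl on an aromatic nitrogen. Among the compounds with values here, the incoming 2-hydroxyethoxy chain brings compound 3 close to compound 1, whose value is the one firm number, so compound 3 is expected to fall below the limit and near the value of compound 1. The expected step, from the limit of compound 2 toward a measurable value, is an at least 2.5-fold lower number from compound 2 to compound 3 (0.39 log units; beyond the scatter). For compound 3 the estimate is 200000 nM, with a range of 60000 nM to 600000 nM, and a fair chance that only a limit is returned.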

Compound 3, half-maximal inhibitory concentration: 155000 nM
Compound 3: middle estimate off by 1.3-fold (0.11 log units), on the high side, and the stated range covers the measured number.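

On the aromatic nitrogen, 2-hydroxyethoxy in place of 1-hydroxyethyl gives an at least 3.2-fold lower number from compound 2 to compound 3 (0.50 log units; beyond the scatter) in this assay, the first step read at this position. Compound 2 has only a limit, so the step is a bound and not a full size: the limit of > 500000 nM in this assay, at which 1 of the 3 values shown sits. At the far end of the chain, hydrogen in place of acetyl on an oxygen on a saturated carbon gives a 1.1-fold higher number from compound 1 to compound 3 (0.06 log units; within the scatter), so the free hydroxyl and its acetyl form cannot be told apart in this assay.

The step from compound 2 alters the chain in more than one way at once, and a plain 2-hydroxyethyl group on the same nitrogen would be needed to separate those changes. Also open, from the compounds shown here alone, is whether a longer chain, or an amine or carboxylic acid at its end, would move the number beyond the scatter.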